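A Fluoro Group Replaces Trifluoromethyl on the Sulfonyl Aryl Ring

A few compounds are considered here, and "the series" means these few. Any claim that something is new, unique, unknown or untested is made for them only; others in the source may bear on it.

In a functional assay on LOX IMVI cells (Homo sapiens) for cytotoxicity, read by MTT assay, with a stated time of 24 h (a lower number here means a stronger inhibitor, a higher number a weaker inhibitor), compound 1 (`O=S(=O)(NCCCNc1nccc(-c2[nH]c(-c3ccccc3)nc2-c2ccc(F)c(O)c2)n1)c1ccc(F)cc1`) gives 19200 nM and compound 2 (`O=S(=O)(NCCCNc1nccc(-c2[nH]c(-c3ccccc3)nc2-c2ccc(F)c(O)c2)n1)c1ccc(C(F)(F)F)cc1`) gives 2450 nM as the lower of the two numbers. The two differ by trifluoromethyl in place of fluoro on an aromatic carbon, and a 7.8-fold lower number from compound 1 to compound 2 (0.89 log units; beyond the scatter) is a modest step beyond the scatter. Compound 3 (`O=S(=O)(NCCCNc1nccc(-c2[nH]c(-c3ccccc3)nc2-c2ccc(F)c(O)c2)n1)c1cccc(F)c1`) is still unmeasured. It carries 3-fluorophenyl in place of 4-(trifluoromethyl)phenyl on a sulfonyl sulfur. Among the measured compounds shown here, the one measured step that bears on this change is a 7.8-fold lower number from compound 1 to compound 2 (0.89 log units; beyond the scatter) when read in reverse, as compound 3 also loses the trifluoromethyl group and carries a fluoro group instead. For the measured compounds named here, no measured compound yet has a 3-fluorophenyl group, so this reading is only a guide. A rise of somewhat smaller size is therefore expected, estimated as a 4.9-fold higher number from compound 2 to compound 3 (0.69 log units; beyond the scatter) in this assay and so still beyond the scatter. Compound 3 is estimated at 12000 nM with 5000 nM to 30000 nM as its expected range.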

Compound 3, half-maximal inhibitory concentration: 7890 nM
Compound 3: the middle estimate sits 1.5-fold (0.18 log units) above what was measured, and the stated range covers the measured number.
By their numbers in this assay, from the lowest: compound 2; then compound 3; then compound 1.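

The result shows that at this position the placement of a single fluoro group can itself shift the reading: in this assay there is a 2.4-fold lower number from compound 1 to compound 3 (0.39 log units; beyond the scatter), with 3-fluorophenyl in place of 4-fluorophenyl on the sulfonyl sulfur. The earlier pair could show only an exchange of fluoro for trifluoromethyl, with both groups carried as 4-substituted phenyl rings. The other new step, a 3.2-fold higher number from compound 2 to compound 3 (0.51 log units; beyond the scatter), shows that 4-(trifluoromethyl)phenyl keeps the lowest number of the three even against 3-fluorophenyl, so the compounds now fall into an order with compound 3 in the middle, though nothing at hand explains this order.

It remains open whether the same shift would hold for the larger group, since a 3-(trifluoromethyl)phenyl ring does not appear among these compounds, and a plain phenyl ring with no fluorine would give the baseline that all three readings lack. Also open, on these data alone, is how far these readings depend on the aryl ring at all, for example with a methoxy group or an amine on that ring, or with a longer chain carrying the sulfonamide nitrogen.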